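Carboxylic acid in place of a thioether amide on the shared core

The source may report more compounds than this note shows. Statements on the series, on what has been measured and on what is new or still open speak of the compounds shown alone.

Measured compounds:
- Compound 1 `COc1ccc(-c2nc(CNC(=O)CSC)sc2-c2ccc(OC)cc2)cc1`: 6 uM
- Compound 2 `COc1ccc(-c2nc(/C=C/C(=O)N3CCN(C)CC3)sc2-c2ccc(OC)cc2)cc1`: 20 uM

In a functional assay (aorta) with Rattus norvegicus as the target (a lower number here means that less compound is needed, a higher number that more compound is needed for the effect), compound 1 gives the lowest of the two numbers, and compound 2 gives 20 uM, a higher number beyond the scatter. Compound 3 `COc1ccc(-c2nc(CCC(=O)O)sc2-c2ccc(OC)cc2)cc1` has not been measured; it differs from compound 1 by carboxymethyl in place of (((methylsulfanyl)methyl)carbonyl)amino on a saturated chain carbon bound to an aromatic carbon. Within the data shown here, no step between measured compounds is known for this change. Compound 3 is expected to need somewhat more compound, an estimated step of a 2.5-fold higher number from compound 1 to compound 3 (0.40 log units; beyond the scatter) in this assay. For compound 3 the estimated value is 15 uM, within a range from 4 uM to 50 uM.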

Compound 3, concentration for half-maximal effect: > 100 uM
Compound 3 was reported as a limit; the forecaster's own chance of this, stated with the estimate: 15%; middle value at least 6.6-fold (0.82 log units) away from the limit.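

Replacing (((methylsulfanyl)methyl)carbonyl)amino with carboxymethyl on a saturated chain carbon bound to an aromatic carbon gives, in this assay, an at least 16-fold higher number from compound 1 to compound 3 (1.22 log units; beyond the scatter). Among these compounds, this shows that the result in this assay is sensitive to the group at this position, which the earlier compounds, differing in more than one place, could not show. The value of compound 3 is a limit and not a number: the limit of > 100 uM in this assay, at which 1 of the 3 values shown sits.

Going by these compounds, it remains open whether the carboxylic acid itself or the departure of the amide and its methylsulfanyl end accounts for the step. A methyl ester or a simple acetamide at this position would separate these two readings.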